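Bromo to Methyl: Expected Effect on Cell Growth Inhibition

The source may report more compounds than this note shows. Statements on the series, on what has been measured and on what is new or still open speak of the compounds shown alone.

Among the compounds with values here, compound 1 `COc1ccc2cc(C(C)c3nnc4n3N=C(c3ccc(Br)cc3)CS4)ccc2c1` is the only compound here with a number: in a functional assay on MCF7 cells (Homo sapiens) for inhibition, read by sulforhodamine B assay, with a stated time of 72 h (on this read-out lower numbers stand for stronger inhibition and higher numbers for weaker inhibition), compound 1 gives 11500 nM, a weak result. Compound 2 `CC(C)Cc1ccc(C(C)c2nnc3n2N=C(c2ccc([N+](=O)[O-])cc2)CS3)cc1` was reported in this assay only as "not active" (no number reported), with no number. Compound 3 `COc1ccc2cc(C(C)c3nnc4n3N=C(c3ccc(C)cc3)CS4)ccc2c1` differs from compound 1 by methyl in place of bromo on an aromatic carbon. Within the data shown here, no measured pair shows this change, so its size is unknown; the expectation is a step in this assay no larger than the usual scatter, in either direction. Compound 3 is therefore estimated at 15000 nM, between 5000 nM and 45000 nM. The expected step is a 1.3-fold higher number from compound 1 to compound 3 (0.12 log units; within the scatter).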

Compound 3, half-maximal inhibitory concentration: 11000 nM
Compound 3: middle estimate off by 1.4-fold (0.13 log units), on the high side; measured number inside the range.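

Within the data shown here, the step of a 1.0-fold lower number from compound 1 to compound 3 (0.02 log units; within the scatter) in this assay gives the first reading at this position: with 4-bromophenyl changed to 4-methylphenyl, the two compounds cannot be told apart. Bromo and methyl are therefore interchangeable here on this core, at least in this assay. Nothing measured here offers a reason for this result. The compounds shown leave open whether an amine or a carboxylic acid at this place would move the number beyond the usual scatter. They also leave open whether a longer chain would do so.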